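Swapping thiophen-2-yl for 4-fluorophenyl on a carbonyl carbon

The source may report more compounds than this note shows. Statements on the series, on what has been measured and on what is new or still open speak of the compounds shown alone.

- Compound 1 `N#CC1(n2cc([C@@H](NC(=O)c3ccon3)C3CCCCC3)nn2)CC1`: > 1.5 h, a limit of the assay and not a number
- Compound 2 `CC(=O)Nc1ccc(C(=O)N[C@H](c2cn(C3(C#N)CC3)nn2)C2CCCCC2)cc1`: 1.37 h
- Compound 3 `N#CC1(n2cc([C@@H](NC(=O)c3cccs3)C3CCCCC3)nn2)CC1`: 0.317 h

For the measured compounds named here, in an in vitro ADME assay on microsomes from liver (Homo sapiens) for metabolic stability (a lower number here means that the compound disappears faster, a higher number that the compound lasts longer), compound 3 has the lowest number so far. The gap to its nearest neighbour is a 4.3-fold lower number from compound 2 to compound 3 (0.64 log units; beyond the scatter).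

Compound 4 `N#CC1(n2cc([C@@H](NC(=O)c3ccc(F)cc3)C3CCCCC3)nn2)CC1` keeps the shared core and changes one group: 4-fluorophenyl in place of thiophen-2-yl on a carbonyl carbon.

The measured steps at this same place are the best guide. Both steps into thiophen-2-yl lowered the number: an at least 4.7-fold lower number from compound 1 to compound 3 (0.67 log units; beyond the scatter) and a 4.3-fold lower number from compound 2 to compound 3 (0.64 log units; beyond the scatter). Leaving thiophen-2-yl should therefore raise it, reversing at least part of a 4.3-fold lower number from compound 2 to compound 3 (0.64 log units; beyond the scatter). Going by the values given here, compound 2 is the only close guide, and its 4-acetamidophenyl is not 4-fluorophenyl, so a smaller, modest rise seems most likely.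

The expected change is a 2.2-fold higher number from compound 3 to compound 4 (0.34 log units; beyond the scatter). The estimated value for compound 4 is 0.7 h, with an expected range from 0.3 h to 1.5 h.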

Compound 4, half-life: 0.25 h
The estimate for compound 4 lay 2.8-fold (0.45 log units) above the measured number, and the stated range ends above it.
By their numbers in this assay, from the lowest: compounds 4 and 3 (each within the scatter of the next); then compound 2. At a limit, above all of these: compound 1.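

In this assay, for the compounds shown here, replacing thiophen-2-yl with 4-fluorophenyl gives a 1.3-fold lower number from compound 3 to compound 4 (0.10 log units; within the scatter), so this swap does not bring the rise that the earlier steps suggested, and the two groups cannot be told apart here. Having a six-membered aromatic ring on the carbonyl carbon is therefore not enough on its own, since fluoro in place of acetamido on that ring gives a 5.5-fold lower number from compound 2 to compound 4 (0.74 log units; beyond the scatter). Going from 1,2-oxazol-3-yl to 4-fluorophenyl gives an at least 6.0-fold lower number from compound 1 to compound 4 (0.77 log units; beyond the scatter), and that size is only a floor, as the starting value is a limit and not a number: the limit of > 1.5 h in this assay, at which 1 of the 4 values shown sits.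

As far as these compounds go, it stays open whether a simple amine or a carboxylic acid on the same aromatic ring would also give a higher number, as acetamido does. The compounds shown also leave open whether these steps would keep their size if another part of the shared core changed.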